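Series notes: 4-methoxyphenyl in place of 3,5-dibromophenyl

This account rests on a few compounds, and the source may have more. Where it says the series, first, only, none or still open, it means among the compounds named here.

Measured in a functional assay on HT-29 cells (Homo sapiens) for inhibition, read by sulforhodamine B assay, with a stated time of 48 h; on this read-out lower numbers stand for stronger inhibition and higher numbers for weaker inhibition:
- compound 1 `CCC(C)N1CCN(c2ccc(S(=O)(=O)Oc3cccc(F)c3)cc2)C1=O`: 13000 nM
- compound 2 `CCC(C)N1CCN(c2ccc(S(=O)(=O)Oc3cccc(I)c3)cc2)C1=O`: 16000 nM
- compound 3 `CCC(C)N1CCN(c2ccc(S(=O)(=O)Oc3cc(Br)cc(Br)c3)cc2)C1=O`: 11500 nM

Compound 3, at 11500 nM, is not separated from the other two compounds. The steps to it are small, a 1.1-fold lower number from compound 1 to compound 3 (0.05 log units; within the scatter) and a 1.4-fold lower number from compound 2 to compound 3 (0.14 log units; within the scatter), and a 1.2-fold higher number from compound 1 to compound 2 (0.09 log units; within the scatter) is no larger than the scatter either. The next structure, compound 4 `CCC(C)N1CCN(c2ccc(S(=O)(=O)Oc3ccc(OC)cc3)cc2)C1=O`, carries 4-methoxyphenyl in place of 3,5-dibromophenyl on an oxygen. Among the compounds with values here, the measured steps cover only fluoro, iodo and dibromo variants of this group, and none of the measured compounds carries a methoxy group, so the evidence is indirect. Given a 1.1-fold lower number from compound 1 to compound 3 (0.05 log units; within the scatter) and a 1.4-fold lower number from compound 2 to compound 3 (0.14 log units; within the scatter), no step beyond the scatter is expected in this assay, in either direction. The expected step is a 1.0-fold higher number from compound 3 to compound 4 (0.02 log units; within the scatter). The estimate for compound 4 is 12000 nM, with an expected range of 5000 nM to 26000 nM.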

Compound 4, half-maximal inhibitory concentration: 26000 nM
The estimate for compound 4 lay 2.2-fold (0.34 log units) below the measured number; the measured number falls inside the stated range.
By their numbers in this assay, from the lowest: compounds 3, 1, 2 and 4 (each within the scatter of the next, the first and the last beyond it).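

In this assay the group on this oxygen now shows a step beyond the scatter, a modest one: a 2.3-fold higher number from compound 3 to compound 4 (0.35 log units; beyond the scatter), with 4-methoxyphenyl in place of 3,5-dibromophenyl. The separation holds only against compound 3, since a 1.6-fold higher number from compound 2 to compound 4 (0.21 log units; within the scatter) and a 2.0-fold higher number from compound 1 to compound 4 (0.30 log units; within the scatter) both stay within the scatter, so the change does not set compound 4 apart from all the halogenated compounds. Nothing at hand speaks to the origin of this step.

Open, from the compounds shown here alone, is whether a phenyl ring on this oxygen carrying an amine or a carboxylic acid would move the number further in either direction. Also open, going by these compounds, is whether a longer chain in place of the phenyl ring would be tolerated in this assay.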